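The compounds below may be only part of what the source reports. "The series", "measured", "known", "first", "only" and "open" are said of these compounds alone.

Working notes on the series, read in a functional assay on SR cells (Homo sapiens) for inhibition, read by sulforhodamine B assay, with a stated time of 48 h, tested at 10 uM; a higher number here means more inhibition of growth at the concentration tested, a lower number less inhibition of growth. Compound 1 (`COc1ccc(-c2nc3sc(-c4ccccc4)cn3n2)cc1`) gives 58%. Compound 2 (`COc1ccc(-c2nc3sc(-c4ccc(Cl)cc4)cn3n2)cc1`) gives 48.9%. Among the compounds with values here, with only these two numbers available, compound 1 stands level with its single neighbour, within the scatter.

The next structure is compound 3 (`c1ccc(-c2nc3sc(-c4ccccc4)cn3n2)cc1`). Its change from compound 1 is hydrogen in place of methoxy on an aromatic carbon. Within the data shown here, the one measured step, a number 9.1 percentage points lower from compound 1 to compound 2 (within the scatter), is chloro in place of hydrogen on an aromatic carbon, and it lies within the scatter. It is made at a different place on the molecule, so it bears on the new change only loosely. Among the measured compounds shown here, no measured pair shows what removing methoxy does, which leaves the expectation poorly anchored.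

No step beyond the scatter is therefore expected, with only a slight lean downward. The estimated step is a number 6 percentage points lower from compound 1 to compound 3 (within the scatter). For compound 3 the expected value is 52%, with an estimated range from 35% to 68%.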

Compound 3, percent growth inhibition at one concentration: 9%
For compound 3 the middle estimate is 43 percentage points above the measured one, outside the stated range (below it).
By their numbers in this assay, from the lowest: compound 3; then compounds 2 and 1 (each within the scatter of the next).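

In this assay, within the data shown here, the position para to a large group, on the six-membered aromatic ring of carbon only, proves far more sensitive than the earlier pair could suggest: hydrogen in place of methoxy gives the first step beyond the scatter (a number 49 percentage points lower from compound 1 to compound 3 (beyond the scatter)). Among these compounds, the only earlier step, with chloro in place of hydrogen at a different place on the molecule, stayed within the scatter (a number 9.1 percentage points lower from compound 1 to compound 2 (within the scatter)), so the methoxy is the one group so far whose removal clearly changes growth inhibition at the concentration tested, though this rests on a single pair. Nothing at hand shows why the loss of this one group has so large a consequence.

Still open, as far as these compounds go, is whether the methoxy itself is needed or whether any group at this position would hold the level of compound 1, a question that a hydroxy, an ethoxy, an amine or a fluoro there would help to settle. Also open, from the compounds shown here alone, is whether the same loss would follow from removing the methoxy from compound 2, which carries the chloro.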